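This account rests on a few compounds, and the source may have more. Where it says the series, first, only, none or still open, it means among the compounds named here.

Compound 1 `Cc1ccc(NC(=S)NC(=O)c2ccc(OCc3cccc(C(F)(F)F)c3)cc2)cc1-c1nc2ccccc2[nH]1` carries a 3-(trifluoromethyl)benzyl ether on the shared core. In a functional assay on MGC-803 cells (Homo sapiens) for inhibition, read by MTT assay, with a stated time of 48 h (a lower number here means a stronger inhibitor, a higher number a weaker inhibitor), compound 1 gives 5210 nM. Of the two numbers in hand it is the higher one; compound 3 `Cc1ccc(COc2ccc(C(=O)NC(=S)Nc3ccc(C)c(-c4nc5ccccc5[nH]4)c3)cc2)cc1` gives 4980 nM, and the step of a 1.0-fold lower number from compound 1 to compound 3 (0.02 log units; within the scatter) stays within the scatter, so the two cannot be ordered. Compound 2 `Cc1ccc(NC(=S)NC(=O)c2ccc(OCc3cccc(Cl)c3Cl)cc2)cc1-c1nc2ccccc2[nH]1` returns only a limit in this assay, > 100000 nM. That limit is the mark at which one of the three values sits (the limit of > 100000 nM in this assay, at which 1 of the 3 values shown sits). The step of an at least 19-fold higher number from compound 1 to compound 2 (1.28 log units; beyond the scatter) is accordingly a large loss, and an at least 20-fold lower number from compound 2 to compound 3 (1.30 log units; beyond the scatter) mirrors it from the other side.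

Compound 4 `Cc1ccc(NC(=S)NC(=O)c2ccc(OCc3ccc(Cl)cc3Cl)cc2)cc1-c1nc2ccccc2[nH]1` has not been measured. The change from compound 1 is 2,4-dichlorophenyl in place of 3-(trifluoromethyl)phenyl on a saturated chain carbon bound to an oxygen on an aromatic ring. Among the measured compounds shown here, two measured steps bear on it: the switch to a dichlorophenyl, as 2,3-dichlorophenyl, gave an at least 19-fold higher number from compound 1 to compound 2 (1.28 log units; beyond the scatter), a large step out to the limit, whereas the switch to 4-methylphenyl gave a 1.0-fold lower number from compound 1 to compound 3 (0.02 log units; within the scatter), nothing beyond the scatter. The 2,4-dichlorophenyl arrangement is untested, so the step expected in this assay is a weakening, likely smaller than that shown by compound 2 but beyond the scatter, with a real chance of another limit. Compound 4 is estimated at 20000 nM, between 5000 nM and 100000 nM, expected as the step of a 3.8-fold higher number from compound 1 to compound 4 (0.58 log units; beyond the scatter).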

Compound 4, half-maximal inhibitory concentration: 3450 nM
Estimate against measurement, compound 4: 5.8-fold (0.76 log units) above; measured number outside the range, below it.
By their numbers in this assay, from the lowest: compounds 4, 3 and 1 (each within the scatter of the next). At a limit, above all of these: compound 2.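

The loss seen at this position does not belong to dichlorophenyl groups as such: in this assay the step of a 1.5-fold lower number from compound 1 to compound 4 (0.18 log units; within the scatter) and the step of a 1.4-fold lower number from compound 3 to compound 4 (0.16 log units; within the scatter) both stay within the scatter, so 2,4-dichlorophenyl cannot be told apart from 3-(trifluoromethyl)phenyl or 4-methylphenyl on the saturated chain carbon bound to an oxygen on an aromatic ring. The arrangement of the two chlorines now matters, since the step of an at least 28-fold lower number from compound 2 to compound 4 (1.46 log units; beyond the scatter) is large although only the 2,3-dichlorophenyl and 2,4-dichlorophenyl patterns differ. Compound 2 is the only compound that goes against the otherwise flat response across these groups, and its value is a limit rather than a number: the limit of > 100000 nM in this assay, at which 1 of the 4 values shown sits.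

From the compounds shown here alone, it remains open whether the loss is confined to the 2,3-dichlorophenyl pattern or would also appear with other groups in the same arrangement, such as two methyl groups or two methoxy groups. Also open, going by these compounds, is whether the flat response holds for an unsubstituted benzyl, or for a benzyl ring carrying an amine or a carboxylic acid.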